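This account rests on a few compounds, and the source may have more. Where it says the series, first, only, none or still open, it means among the compounds named here.

Measured in a functional assay on DU-145 cells (Homo sapiens) for inhibition, read by trypan blue exclusion, with a stated time of 72 h; on this read-out lower numbers stand for stronger inhibition and higher numbers for weaker inhibition:
- compound 1 `Cn1c(=O)c(C(=O)Nc2ccc(F)cc2F)cc2cnc(Nc3ccc4[nH]ccc4c3)nc21`: 5000 nM
- compound 2 `CCCn1c(=O)c(S(=O)(=O)c2ccc(F)cc2F)cc2cnc(Nc3ccc4[nH]ccc4c3)nc21`: 1000 nM

Compound 1 has the higher of these two numbers, and the gap to compound 2 lies beyond the scatter. The two differ in more than one place, so no single change can be read from them. Compound 3 `Cn1c(=O)c(S(=O)(=O)c2ccc(O)cc2)cc2cnc(Nc3ccc4[nH]ccc4c3)nc21` is still unmeasured. Compared with compound 1, it has (4-hydroxyphenyl)sulfonyl in place of (2,4-difluorophenyl)carbamoyl on an aromatic carbon. Compound 2 also carries a sulfonyl group and gives 1000 nM, so a moderate move towards lower numbers in this assay is expected. The expected change is a 3.3-fold lower number from compound 1 to compound 3 (0.52 log units; beyond the scatter). For compound 3 the estimated value is 1500 nM, with a range of 300 nM to 6000 nM.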

Compound 3, half-maximal inhibitory concentration: 250 nM
Beside the measured number, compound 3's estimate is 6.0-fold (0.78 log units) above it; measured number below the stated range.
By their numbers in this assay, from the lowest: compound 3; then compound 2; then compound 1.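

Putting (4-hydroxyphenyl)sulfonyl in place of (2,4-difluorophenyl)carbamoyl on this aromatic carbon in this assay gives a 20-fold lower number from compound 1 to compound 3 (1.30 log units; beyond the scatter) and shows that this position can strongly shift the read-out. The link to the core and the groups on the phenyl ring change together in this single step. Nothing available here explains the size of the step. Whether the sulfonyl or the hydroxy group accounts for more of it stays open. A methoxy group or an amine in place of that hydroxy group would help to separate the two.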